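Same-atom group swap on the shared core: working notes

The compounds below may be only part of what the source reports. "The series", "measured", "known", "first", "only" and "open" are said of these compounds alone.

In an ADME assay on microsomes from liver (Rattus norvegicus) for metabolic stability, using NADPH, with a stated time of 10 min (on this read-out lower numbers stand for a less stable compound and higher numbers for a more stable compound), compound 1 `CN(C)[C@@H]1CCN(c2cccc3c2C[C@H](CN(C)[C@H]2CCCc4cccnc42)NC3)C1` gives 3.88% and compound 2 `CN1CC[C@H]2CN(c3cccc4c3C[C@H](CN(C)[C@H]3CCCc5cccnc53)NC4)C[C@H]21` gives 1.78%, so compound 2 stands within the scatter of compound 1. Compound 3 `CN1C[C@@H]2CN(c3cccc4c3C[C@H](CN(C)[C@H]3CCCc5cccnc53)NC4)C[C@@H]2C1` has the same atoms as compound 2, joined differently: a group of 9 heavy atoms (7 carbon, 2 nitrogen; 2 five-membered non-aromatic rings with 1 hetero atom each) in place of a group of 9 heavy atoms (7 carbon, 2 nitrogen; 2 five-membered non-aromatic rings with 1 hetero atom each), on an aromatic carbon. The site is an aromatic carbon of a six-membered aromatic ring of carbon only, part of a fused or bridged system of two rings. Among the compounds with values here, one measured step bears on this change, as it also exchanges the group on that aromatic carbon: a number 2.1 percentage points lower from compound 1 to compound 2 (within the scatter). This single small step gives no direction, so no step beyond the scatter is expected in this assay. The expected step is a number 1.2 percentage points higher from compound 2 to compound 3 (within the scatter). Compound 3 is estimated at 3%, with an expected range of 0.5% to 10%.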

Compound 3, percent of the compound remaining: 35.3%
Compound 3: the middle estimate sits 32.3 percentage points below what was measured; the whole stated range lies below it.
By their numbers in this assay, from the lowest: compounds 2 and 1 (each within the scatter of the next); then compound 3.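

In this assay this aromatic carbon proves sensitive to how the group on it is joined, not only to which atoms it carries: the exchange gives a number 33.5 percentage points higher from compound 2 to compound 3 (beyond the scatter) even though the leaving and entering groups print the same heavy atoms, ring counts, hydrogen-bond counts and number of defined stereocentres. The entering group also gives a number 31.4 percentage points higher from compound 1 to compound 3 (beyond the scatter) against the group with one five-membered ring, so a large step at this position now stands where the earlier exchange stayed within the scatter. No measurement shown here offers a reason for either step.

The compounds shown leave open whether this read-out holds when the stereocentres of the entering group are inverted. They also leave open how a piperazine or a morpholine on the same aromatic carbon would read in this assay on the shared core.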